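Amine replacement on the core of compound 2

The compounds below may be only part of what the source reports. "The series", "measured", "known", "first", "only" and "open" are said of these compounds alone.

The series shares the core seen in compound 2 `COCc1cc(OC)c(-c2nc3c(C)ccc(N(CC4CCOCC4)CC4CC4)c3cc2C)c(OC)c1`, compound 3 `COCc1cc(OC)c(-c2nc3c(C)ccc(N(CC4CC4)C4CCOCC4)c3cc2C)c(OC)c1` and compound 1 `CCCN(CCC)c1ccc(C)c2nc(Oc3c(OC)cc(COC)cc3OC)c(C)cc12`. In an assay on HEK293 cells for displacement of a labelled ligand from corticotropin-releasing factor receptor 1 (Homo sapiens), with a stated time of 2 h (a lower number here means a stronger inhibitor, a higher number a weaker inhibitor), compound 2 gives 286 nM, the highest of the two numbers recorded, and compound 3 gives 246 nM. The step of a 1.2-fold lower number from compound 2 to compound 3 (0.07 log units; within the scatter) shows that exchanging (oxan-4-yl)methyl for oxan-4-yl on a nitrogen on an aromatic ring changes little. Compound 1 returns only a limit, > 1000 nM, as recorded in the limit of > 1000 nM in this assay, at which 1 of the 3 values shown sits. Compound 4 `COCCNc1ccc(C)c2nc(-c3c(OC)cc(COC)cc3OC)c(C)cc12` is the next member. It differs from compound 2 in one place: (2-methoxyethyl)amino in place of (cyclopropylmethyl)((oxan-4-yl)methyl)amino on an aromatic carbon. Within the data shown here, no measured step covers a change of this kind; the single step recorded stays within the scatter and swaps one saturated ring for another on the same nitrogen, while compound 1 differs elsewhere in the structure. Both saturated rings leave and a short chain with a hydrogen-bond donor enters, so the step of a 5.2-fold higher number from compound 2 to compound 4 (0.72 log units; beyond the scatter) is expected to run toward a higher number, beyond the scatter, with wide uncertainty. Compound 4 is therefore estimated at 1500 nM, in the range 400 nM to 6000 nM, with a real chance that this assay returns only a limit.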

Compound 4, half-maximal inhibitory concentration: > 1000 nM
Compound 4: only a limit was reported; the forecaster's own chance of this, stated with the estimate: 50%; the middle value does not contradict the limit.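

Where the earlier step only exchanged one saturated ring for another on the same nitrogen, this change removes both rings from the amine on the aromatic carbon para to a methyl group, and the number moves beyond the scatter in this assay: an at least 3.4-fold higher number from compound 2 to compound 4 (0.54 log units; beyond the scatter) and an at least 4.0-fold higher number from compound 3 to compound 4 (0.60 log units; beyond the scatter). Compound 4 gives only a limit, > 1000 nM, so both steps are lower bounds: the limit of > 1000 nM in this assay, at which 2 of the 4 values shown sit. At this position, the two ring-bearing amines of compound 2 and compound 3 read alike, while (2-methoxyethyl)amino does not match them.

The compounds shown do not separate the departure of the rings from the arrival of the hydrogen-bond donor. A secondary amine carrying only cyclopropylmethyl, or a tertiary amine with a methyl group added to the nitrogen of (2-methoxyethyl)amino, would pull the two apart.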